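Substituent Variation at the Aromatic Nitrogen: Halogenated Benzyl Analogue

The compounds below may be only part of what the source reports. "The series", "measured", "known", "first", "only" and "open" are said of these compounds alone.

Compound 2 `C=C(C)Cn1cc(/C=C/C(=O)CC(=O)C(=O)OCC)c2ccccc21` carries a 2-methylprop-2-en-1-yl group on the aromatic nitrogen of the shared core. In an assay on isolated protein for inhibition of DNA nucleotidylexotransferase (Homo sapiens), read by scintillation counting, with a stated time of 10 min (on this read-out lower numbers stand for stronger inhibition and higher numbers for weaker inhibition), compound 2 returns only a limit, > 40 uM, and not a number. Its two measured neighbours stand at the same point. Compound 1 `C/C=C/n1cc(/C=C/C(=O)CC(=O)C(=O)OCC)c2ccccc21` likewise gives only the limit > 40 uM in this assay. Compound 3 `CCOC(=O)C(=O)CC(=O)/C=C/c1cn(Cc2ccccc2)c2ccccc12`, the benzyl analogue, also reaches only the limit > 40 uM in this assay. All three values therefore sit at one place, as summarised by the limit of > 40 uM in this assay, at which 3 of the 3 values shown sit.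

Compound 4 `CCOC(=O)C(=O)CC(=O)/C=C/c1cn(Cc2ccc(F)cc2)c2ccccc12` is the next member: 4-fluorophenyl in place of 1-methylethenyl on a saturated chain carbon bound to an aromatic nitrogen. The measured steps that touch the same position, a step that the two limits leave unreadable from compound 1 to compound 2, a step that the two limits leave unreadable from compound 1 to compound 3 and a step that the two limits leave unreadable from compound 2 to compound 3, are all unreadable in size and direction, since each begins and ends at a limit. Going by the values given here, no step among the measured compounds has yielded a number, so nothing among them points to a readable change for this replacement; the closest measured relative, compound 3, stands at the limit alone.

The expectation for compound 4 is therefore a step that the limit leaves unreadable from compound 2 to compound 4, most likely again unreadable. Compound 4 is estimated at 60 uM in this assay, with a range from 15 uM to 250 uM.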

Compound 4, concentration for 50% inhibition: > 40 uM
Compound 4: a limit, no number (the forecaster's own chance of this, stated with the estimate: 75%); the middle value lies beyond the limit too.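

In this assay compound 4 gives > 40 uM, a limit and not a number. No step from compound 1, compound 2 or compound 3 to compound 4 can be read in size or direction: the limit of > 40 uM in this assay, at which 4 of the 4 values shown sit.

The compounds shown leave open whether any group on the aromatic nitrogen, 4-fluorobenzyl included, can give a readable value in this assay.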